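The source may hold more compounds than are shown below. What is called first, only, known or untested is meant among the compounds shown, and "the series" means these compounds.

Of the compounds shown here, three built on one shared core have been tested so far. Compound 1 `CCCSc1nc(N/N=C/c2cccnc2)c2nnn(Cc3ccccc3)c2n1` carries a pyridin-3-yl group on the hydrazone carbon. In a functional assay on MCF7 cells (Homo sapiens) for antiproliferative activity, read by MTT assay, with a stated time of 72 h (on this read-out higher numbers stand for weaker inhibition and lower numbers for stronger inhibition), compound 1 gives 58700 nM, the highest number of the three, which on this read-out means the weakest inhibition of cell growth. Compound 2 `C#CCSc1nc(N/N=C(\C)c2ccccc2O)c2nnn(Cc3ccccc3)c2n1` gives 11300 nM in this assay, and compound 3 `C#CCSc1nc(N/N=C/c2cc(OC)c(OC)c(OC)c2)c2nnn(Cc3ccccc3)c2n1` gives 17000 nM; both of these numbers lie below that of compound 1 by more than the usual scatter of repeated measurements, so compound 1 is the least potent of the three. Compounds 2 and 3 differ from compound 1 in more than one place, so no single change can be read off from them.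

Compound 4 `CCCSc1nc(N/N=C/c2ccc([N+](=O)[O-])cc2)c2nnn(Cc3ccccc3)c2n1` has not yet been tested. It differs from compound 1 in one place: 4-nitrophenyl in place of pyridin-3-yl on a carbon with a double bond to nitrogen. Within the data shown here, no directly comparable pair has been measured, so the size of this step is uncertain. Because compound 1 sits at 58700 nM and the two other measured compounds, which also carry substituted phenyl groups on that carbon, give lower numbers, a modest move toward stronger inhibition is expected, with a 2.0-fold lower number from compound 1 to compound 4 (0.29 log units; within the scatter) as the estimated step. Compound 4 is therefore expected to give about 30000 nM in this assay, within a range from 10000 nM to 90000 nM.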

Compound 4, half-maximal inhibitory concentration: 11000 nM
Compound 4: the middle estimate sits 2.7-fold (0.44 log units) above what was measured; measured number inside the range.
By their numbers in this assay, from the lowest: compounds 4, 2 and 3 (each within the scatter of the next); then compound 1.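

Among these compounds, this is the first pair in the set that differs in one place only, so a single change can now be read. In this assay, putting 4-nitrophenyl in place of pyridin-3-yl on a carbon with a double bond to nitrogen, with the rest of the molecule unchanged, gives a 5.3-fold lower number from compound 1 to compound 4 (0.73 log units; beyond the scatter), and a lower number here means stronger inhibition of cell growth. This shows that the group at this position affects the read-out, although the swap replaces a ring holding one nitrogen with a ring of carbon only and adds a nitro group in the same step, and no measurement shown explains the difference.

The ring and the nitro group therefore remain inseparable: an unsubstituted phenyl at this place would show what the ring alone contributes, while a 4-aminophenyl or 4-carboxyphenyl would show whether other groups at that ring position give a similar number. Also open, as far as these compounds go, is whether the same swap would give a step of similar size on a core with a different chain in place of the propyl group, or in other cell lines.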